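Amide aryl change from compound 3 to compound 4

The source may report more compounds than this note shows. Statements on the series, on what has been measured and on what is new or still open speak of the compounds shown alone.

Compound 3 `Cc1ccc(C(=O)Nc2ccc(Cl)c(-c3ccccn3)c2)c(C)n1` stands second highest of the three numbers in an assay on C3H 10T1/2 cells for inhibition of Sonic hedgehog protein (Mus musculus), read by a luciferase reporter; on this read-out higher numbers stand for weaker inhibition and lower numbers for stronger inhibition: compound 1 `Cc1nc(C(F)(F)F)ccc1C(=O)Nc1ccc(Cl)c(-c2nc3ccccc3[nH]2)c1` gives 12 nM, compound 2 `Cc1nc(C(F)(F)F)ccc1C(=O)Nc1ccc(Cl)c(-c2ncccn2)c1` gives 8000 nM, and compound 3 gives 130 nM. For the measured compounds named here, the only single-place step so far, a 670-fold higher number from compound 1 to compound 2 (2.82 log units; beyond the scatter), concerns the ring on the aromatic carbon, not the amide side. Compound 4 `O=C(Nc1ccc(Cl)c(-c2ccccn2)c1)c1ccccc1` differs from compound 3 by phenyl in place of 2,6-dimethylpyridin-3-yl on a carbonyl carbon. Going by the values given here, no measured step touches the carbonyl carbon, so there is nothing to weigh this change against, and the expectation is correspondingly wide. A moderate weakening is expected, a 3.1-fold higher number from compound 3 to compound 4 (0.49 log units; beyond the scatter). Compound 4 is estimated at 400 nM, within 80 nM to 2500 nM, in this assay.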

Compound 4, half-maximal inhibitory concentration: 800 nM
Compound 4: the middle estimate sits 2.0-fold (0.30 log units) below what was measured, and the stated range covers the measured number.
By their numbers in this assay, from the lowest: compound 1; then compound 3; then compound 4; then compound 2.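

On the carbonyl carbon, the aryl group matters in this assay: phenyl in place of 2,6-dimethylpyridin-3-yl gives a 6.2-fold higher number from compound 3 to compound 4 (0.79 log units; beyond the scatter). This first change on the amide side is a smaller step than a 670-fold higher number from compound 1 to compound 2 (2.82 log units; beyond the scatter), which concerns the ring on the aromatic carbon. Nothing available gives a reason for the weakening.

Which part of 2,6-dimethylpyridin-3-yl accounts for the step remains open: an unsubstituted pyridin-3-yl or a 2,6-dimethylphenyl would separate the ring nitrogen from the methyl groups. On these data alone, the effect of an amine on the phenyl also remains open.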